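This account rests on a few compounds, and the source may have more. Where it says the series, first, only, none or still open, it means among the compounds named here.

Compound 1 `O=C(NCc1ccc(F)cc1F)c1c(O)c2cc(CCCCCO)cnc2n(O)c1=O`: > 250000 nM (a limit of the assay)
Compound 2 `Nc1c(C(=O)NCc2ccc(F)cc2F)c(=O)n(O)c2ncc(CCCCCCOCc3ccccc3)cc12`: 14400 nM

Among the measured compounds shown here, in an ADME assay on HOS cells (Homo sapiens) for cytotoxicity, read by luminescence and ATP content, with a stated time of 48 h (on this read-out higher numbers stand for lower toxicity in this test and lower numbers for higher toxicity in this test), compound 2 gives 14400 nM, the only actual number so far. Compound 3 `Nc1c(C(=O)NCc2ccc(F)cc2F)c(=O)n(O)c2ncc(CCc3ccccc3)cc12` keeps the core of compound 2 but carries phenyl in place of 4-(benzyloxy)butyl on a saturated chain carbon, two bonds along the chain from an aromatic carbon. For the measured compounds named here, no measured step yet shows what such a change does, so this is a tentative judgement: a moderate move to higher numbers, beyond the scatter, is expected. The estimated change is a 2.8-fold higher number from compound 2 to compound 3 (0.44 log units; beyond the scatter). For compound 3 the expected value is 40000 nM, with an estimated range of 10000 nM to 200000 nM.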

Compound 3, half-maximal cytotoxic concentration: 18000 nM
Beside the measured number, compound 3's estimate is 2.2-fold (0.35 log units) above it; low and high end bracket the measured number.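

In this assay, this first measured step at the position is a 1.3-fold higher number from compound 2 to compound 3 (0.10 log units; within the scatter). Phenyl in place of 4-(benzyloxy)butyl on a saturated chain carbon, two bonds along the chain from an aromatic carbon, therefore gives no change that can be told from the scatter, even though the entering group has fewer heavy atoms and no oxygen.

Compound 1 differs from both in more than one place and offers only a limit, not a number: the limit of > 250000 nM in this assay, at which 1 of the 3 values shown sits.

From the compounds shown here alone, whether an amine, a carboxylic acid or a longer chain at this place would move the read-out remains open.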